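From methylsulfonyl to a larger sulfonyl group

A few compounds are considered here, and "the series" means these few. Any claim that something is new, unique, unknown or untested is made for them only; others in the source may bear on it.

- Compound 1 `CC1=C2C[C@H]3[C@@H](CC[C@@H]4Cc5nn(C)cc5C[C@@]43C)[C@@H]2CC[C@@]2(C1)O[C@@H]1C[C@H](C)CN[C@H]1[C@H]2C`: 0.583 h
- Compound 2 `CC1=C2C[C@H]3[C@@H](CC[C@@H]4Cc5nn(S(C)(=O)=O)cc5C[C@@]43C)[C@@H]2CC[C@@]2(C1)O[C@@H]1C[C@H](C)CN[C@H]1[C@H]2C`: 3 h

Among the measured compounds shown here, in an in vitro ADME assay on microsomes from liver (Homo sapiens) for metabolic stability, tested at 500 nM (on this read-out higher numbers stand for a longer-lived compound and lower numbers for a shorter-lived compound), compound 2 gives 3 h, the higher of the two numbers so far. For the measured compounds named here, the only measured step is a 5.1-fold higher number from compound 1 to compound 2 (0.71 log units; beyond the scatter), with methylsulfonyl in place of methyl on an aromatic nitrogen. Compound 3 `CC1=C2C[C@H]3[C@@H](CC[C@@H]4Cc5nn(S(=O)(=O)c6ccc(C)cc6)cc5C[C@@]43C)[C@@H]2CC[C@@]2(C1)O[C@@H]1C[C@H](C)CN[C@H]1[C@H]2C` keeps the sulfonyl on that nitrogen and changes what the sulfur carries: 4-methylphenyl in place of methyl on a sulfonyl sulfur. In words, this is 4-methylphenyl in place of methyl on a sulfonyl sulfur. Going by the values given here, the measured step bears on this only loosely, since no measured pair shows a change at the sulfonyl sulfur. Compound 2 tops this short series, so a small downward step is expected, perhaps one that stays within the usual scatter. The estimated change is a 1.5-fold lower number from compound 2 to compound 3 (0.18 log units; within the scatter). Compound 3 is estimated at 2 h, with an expected range from 0.7 h to 5 h.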

Compound 3, half-life: 1.08 h
Compound 3: middle estimate off by 1.9-fold (0.27 log units), on the high side, and the stated range covers the measured number.
By their numbers in this assay, from the lowest: compounds 1 and 3 (each within the scatter of the next); then compound 2.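

In this assay, what the sulfonyl sulfur carries matters: 4-methylphenyl in place of methyl gives a 2.8-fold lower number from compound 2 to compound 3 (0.44 log units; beyond the scatter), a step beyond the usual scatter. A sulfonyl group on the aromatic nitrogen is therefore not enough on its own to hold the longer half-life, since (4-methylphenyl)sulfonyl in place of methyl gives a 1.9-fold higher number from compound 1 to compound 3 (0.27 log units; within the scatter), a step within the scatter, so those two compounds cannot be told apart on this read-out. Nothing available here explains why the half-life responds to this change.

Going by these compounds, it remains open whether the drop follows the phenyl ring itself or the methyl on it, which a plain phenyl on the sulfur would help to separate. Also open, on these data alone, is how a small ethyl or cyclopropyl group, or a dimethylamino group, would behave at this sulfur.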